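Same Aryl Substituent Swap, Repeated on a Second Core

The source may hold more compounds than are shown below. What is called first, only, known or untested is meant among the compounds shown, and "the series" means these compounds.

Of the compounds shown here, three have been measured in a functional assay on VCaP cells (Homo sapiens) for antiproliferative activity, read by propidium iodide staining, with a stated time of 96 h; on this read-out higher numbers stand for weaker inhibition and lower numbers for stronger inhibition. Compound 1, `CC(O)(CSc1ccc(S(F)(F)(F)(F)F)cc1)C(=O)Nc1ccc(S(F)(F)(F)(F)F)cc1`, gives 28000 nM in this assay. Compound 2, `CC(O)(CSc1ccc(OC(F)(F)F)cc1)C(=O)Nc1ccc(S(F)(F)(F)(F)F)cc1`, gives 16000 nM. Compound 3, `CC(O)(COc1ccc(S(F)(F)(F)(F)F)cc1)C(=O)Nc1ccc(S(F)(F)(F)(F)F)cc1`, gives 9300 nM, the lowest of the three numbers; its gap to compound 2 lies within the scatter, while its gap to compound 1 lies beyond it.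

Compound 1 and compound 2 differ in one place: a group of 5 heavy atoms (1 carbon, 1 oxygen, 3 fluorine; no ring) in place of a group of 6 heavy atoms (5 fluorine, 1 sulfur; no ring), on an aromatic carbon. This change brought a 1.8-fold lower number from compound 1 to compound 2 (0.24 log units; within the scatter). Compound 3 and compound 1 differ in more than one place, and the difference between the two cores is not broken down here.

Compound 4, `CC(O)(COc1ccc(OC(F)(F)F)cc1)C(=O)Nc1ccc(S(F)(F)(F)(F)F)cc1`, has not yet been measured in this assay. It stands to compound 3 as compound 2 stands to compound 1: a group of 5 heavy atoms (1 carbon, 1 oxygen, 3 fluorine; no ring) in place of a group of 6 heavy atoms (5 fluorine, 1 sulfur; no ring), on an aromatic carbon. The surroundings of the place are described in the same words in both cases, so this is the same change made on a second core.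

For compound 4 the step expected from this change is a 1.7-fold lower number from compound 3 to compound 4 (0.23 log units; within the scatter), to be set beside the measured 1.8-fold lower number from compound 1 to compound 2 (0.24 log units; within the scatter). This expectation rests on that earlier step and on the starting value of compound 3, 9300 nM. The earlier step lay within the scatter. The range given is therefore wide.

Compound 4 is estimated to give 5500 nM in this assay, between 2500 nM and 12000 nM.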

Compound 4, half-maximal inhibitory concentration: 12800 nM
The estimate for compound 4 lay 2.3-fold (0.37 log units) below the measured number, outside the stated range (above it).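

In this assay, setting trifluoromethoxy in place of the group of five fluorines and one sulfur on the second core gave a 1.4-fold higher number from compound 3 to compound 4 (0.14 log units; within the scatter), which, like the earlier step, lies within the scatter. Placed side by side, the two steps cannot be told apart in this series: the same change on two cores in this assay, a 1.8-fold lower number (0.24 log units; within the scatter) from compound 1 to compound 2 and a 1.4-fold higher number (0.14 log units; within the scatter) from compound 3 to compound 4, 2.4-fold (0.38 log units) apart, within the scatter of two such steps This shows only that the change has no effect beyond the scatter on either core and that the two cores give no sign of treating it differently; it does not show that the change carries the same effect from one core to the other, and with two small steps neither a shared effect nor an opposed one can be read from these compounds.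

The four compounds cover just two groups at this place and two cores, so they leave open whether the step would remain this small with a nitrile, a trifluoromethyl or an amine at the same place, where a larger step could be read more clearly. They also leave open whether the result would hold if a carboxylic acid or a longer chain stood elsewhere in the shared part of the molecule.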